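The source may hold more compounds than are shown below. What is called first, only, known or untested is meant among the compounds shown, and "the series" means these compounds.

Three compounds have been measured in a functional assay on HEK293 cells for activation of melanin-concentrating hormone receptor 1 (Rattus norvegicus), read by inositol phosphate accumulation; on this read-out higher numbers stand for an effect only at larger amounts of compound and lower numbers for an effect already at smaller amounts:

compound 1, `CC(C)N(C)c1ccc2cc(NC(=O)CCc3ccc(C(F)(F)F)cc3)ccc2n1`, gives 140 nM
compound 2, `CN(c1ccc2cc(NC(=O)CCc3ccc(C(F)(F)F)cc3)ccc2n1)C1CCCC1`, gives 350 nM
compound 3, `O=C(CCc1ccc(C(F)(F)F)cc1)Nc1ccc2nc(N3CCCCC3)ccc2c1`, gives 110 nM

Compound 1 holds the second highest of these three numbers. Its nearest neighbour is compound 3, with a 1.3-fold lower number from compound 1 to compound 3 (0.10 log units; within the scatter). The furthest from it is compound 2, with a 2.5-fold higher number from compound 1 to compound 2 (0.40 log units; beyond the scatter). Between the other two, a 3.2-fold lower number from compound 2 to compound 3 (0.50 log units; beyond the scatter).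

The next compound, compound 4, `CCN(CC)c1ccc2cc(NC(=O)CCc3ccc(C(F)(F)F)cc3)ccc2n1`, differs from compound 1 in one place: diethylamino in place of isopropyl(methyl)amino on an aromatic carbon.

Two of the measured steps bear on this. The step from compound 1 to compound 2 exchanged one branch of the amine for a larger ring and moved the number up modestly, while the step from compound 1 to compound 3 rewrote the whole amine as piperidin-1-yl and left the number within the scatter. The change to compound 4 keeps the same atoms and only rejoins them, which looks more like the second of these steps than the first. The step from compound 1 to compound 4 is therefore expected to stay within the scatter, a 1.1-fold higher number from compound 1 to compound 4 (0.03 log units; within the scatter). For compound 4 the expected value in this assay is 150 nM, with a likely range from 70 nM to 350 nM.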

Compound 4, half-maximal effective concentration: 830 nM
Beside the measured number, compound 4's estimate is 5.5-fold (0.74 log units) below it, and the stated range ends below it.
By their numbers in this assay, from the lowest: compounds 3 and 1 (each within the scatter of the next); then compound 2; then compound 4.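

At this aromatic carbon, next to the ring nitrogen, isopropyl(methyl)amino and diethylamino have the same count of heavy atoms, and neither has a ring, yet in this assay the exchange gives a 5.9-fold higher number from compound 1 to compound 4 (0.77 log units; beyond the scatter) and so the count of atoms alone does not set the number here. The open-chain diethylamino also stands apart from both ring-bearing amines, with a 7.5-fold higher number from compound 3 to compound 4 (0.88 log units; beyond the scatter) against piperidin-1-yl and a 2.4-fold higher number from compound 2 to compound 4 (0.38 log units; beyond the scatter) against cyclopentyl(methyl)amino, which leaves compound 4 with the highest number of the four, but compound 1 goes against any simple rule that open-chain amines do worse, since it also has no ring and its number lies within the scatter of that of compound 3. Nothing measured here explains why joining the same atoms differently has so large an effect.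

The compounds shown leave open whether a smaller amine such as dimethylamino or ethyl(methyl)amino would fall with compound 1 and compound 3 or with compound 4. They also leave open how a pyrrolidin-1-yl or morpholin-4-yl ring would compare with the piperidin-1-yl of compound 3.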